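Enlarging the Amine Ring on a Shared Core

The source may report more compounds than this note shows. Statements on the series, on what has been measured and on what is new or still open speak of the compounds shown alone.

Compound 1 `c1cc(N2CCCCC2)nc(Nc2ccc(Oc3ncnc4sccc34)cc2)n1`: 40.4%
Compound 2 `c1cc(N2CCCC2)nc(Nc2ccc(Oc3ncnc4sccc34)cc2)n1`: 24.7%

Both were tested in a functional assay on MDA-MB-231 cells (Homo sapiens) for inhibition, read by MTT assay, with a stated time of 72 h, tested at 20 uM; on this read-out lower numbers stand for less inhibition and higher numbers for more inhibition at the one concentration tested (going by the name of the read-out). For the measured compounds named here, compound 2 stands lowest of the two numbers; the only measured step, a number 15.7 percentage points lower from compound 1 to compound 2 (beyond the scatter), is modest yet beyond the scatter, and the smaller ring gave the lower number. Compound 3 `c1ccc2c(c1)CCN2c1ccnc(Nc2ccc(Oc3ncnc4sccc34)cc2)n1` is not yet measured and differs from compound 2 by 2,3-dihydro-1H-indol-1-yl in place of pyrrolidin-1-yl on an aromatic carbon. Going by the values given here, that one step is the sole guide, and it points toward a larger group giving more inhibition, though the new group is far larger than either ring measured. Compound 3 is expected to give about 38%, between 15% and 60%, an estimated rise of a number 13.3 percentage points higher from compound 2 to compound 3 (beyond the scatter).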

Compound 3, a percentage reported as inhibition, at one concentration (the size of the read-out at that concentration, not a potency): 9.95%
For compound 3 the middle estimate is 28.1 percentage points above the measured one, and the stated range ends above it.
By their numbers in this assay, from the lowest: compound 3; then compound 2; then compound 1.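

In this assay this position does not simply reward a larger group: replacing pyrrolidin-1-yl with 2,3-dihydro-1H-indol-1-yl, which adds a six-membered aromatic ring of carbon only, gives a number 14.8 percentage points lower from compound 2 to compound 3 (beyond the scatter) and the same group in place of piperidin-1-yl gives a number 30.5 percentage points lower from compound 1 to compound 3 (beyond the scatter) here. The largest group thus has the lowest number, so the link between a larger ring and a higher number does not extend to it. Nothing available explains this result. Still open, from the compounds shown here alone, is how a morpholin-4-yl ring or an open-chain amine such as dimethylamino would read at this position.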